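Phenyl for Ethyl on Sulfur: Expected Cytotoxicity Reading

This account rests on a few compounds, and the source may have more. Where it says the series, first, only, none or still open, it means among the compounds named here.

Of the compounds shown here, two have so far been measured in an ADME assay on Vero cells (Chlorocebus sabaeus) for cytotoxicity; on this read-out lower numbers stand for higher toxicity in this test and higher numbers for lower toxicity in this test. Compound 1 `CC(C)COc1ccc(-c2nn3ccc(NC4CCCC4)cc3c2-c2ccnc(NC3CCCC3)n2)cc1` gives 27000 nM. Compound 2 `CCSc1cc(NC2CCCC2)cc2c(-c3ccnc(NC4CCCC4)n3)c(-c3ccc(OC)cc3)nn12` is reported as > 40000 nM, which is a limit of this assay and not a measured number. Compound 2 thus stands at the limit of > 40000 nM in this assay, at which 1 of the 2 values shown sits, and how far beyond that it lies is not known. Within the data shown here, no step between the two measured compounds has been worked out, so their two values can only be set side by side.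

Compound 3 `COc1ccc(-c2nn3c(Sc4ccccc4)cc(NC4CCCC4)cc3c2-c2ccnc(NC3CCCC3)n2)cc1` has not yet been measured. It differs from compound 2 in one place: phenyl in place of ethyl on a sulfur. Nothing measured here bears on what this exchange does to the reading in this assay. The expected step is an at least 1.1-fold lower number from compound 2 to compound 3 (0.05 log units; that floor lies within the scatter), which is none beyond the scatter. Compound 3 is accordingly estimated at 35000 nM, with a range from 15000 nM to 80000 nM, and a fair chance that it too is reported only as a limit.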

Compound 3, half-maximal cytotoxic concentration: > 40000 nM
Compound 3 ended at the assay's limit; the forecaster's own chance of this, stated with the estimate: 50%; middle value at least 1.1-fold (0.05 log units) away from the limit.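

Compound 2 and compound 3 both end at a limit of this assay and not at a measured number, so no step between them can be read: the limit of > 40000 nM in this assay, at which 2 of the 3 values shown sit.

The compounds shown leave open how far past that limit each one lies, and whether phenyl in place of ethyl on a sulfur changes the reading at all.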